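Adding chloro to the benzamido ring of compound 2

The source may report more compounds than this note shows. Statements on the series, on what has been measured and on what is new or still open speak of the compounds shown alone.

In a functional assay on MDA-MB-231 cells (Homo sapiens) for antiproliferative activity, with a stated time of 4 days (on this read-out higher numbers stand for weaker inhibition and lower numbers for stronger inhibition), compound 1 (`CCCCc1ccc2[nH]c(-c3ccc(OC)cc3)c(/C=N/O)c2c1`) gives 40 nM as its measured value. Among the compounds with values here, compound 2 (`CCCCc1ccc2[nH]c(-c3ccc(OC)cc3)c(/C=N/NC(=O)c3ccccc3)c2c1`) gives 32 nM in the same read-out, within the scatter of compound 1, so the two stand level on the numbers so far.

Compound 3 (`CCCCc1ccc2[nH]c(-c3ccc(OC)cc3)c(/C=N/NC(=O)c3ccc(Cl)cc3)c2c1`) has chloro in place of hydrogen on an aromatic carbon, para to a large group. Its difference from compound 2 is chloro in place of hydrogen on an aromatic carbon (phenyl to 4-chlorophenyl).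

Within the data shown here, only one measured step is available, and it bears on this change only loosely. That step, a 1.3-fold lower number from compound 1 to compound 2 (0.10 log units; within the scatter) on exchanging hydroxy for benzamido on a double-bonded nitrogen, stayed within the scatter. It does not test any substituent on the ring that changes here, so the data give no direct guide to the effect of chloro. No step beyond the scatter is therefore expected in this assay for compound 3. The expected move is a 1.1-fold higher number from compound 2 to compound 3 (0.04 log units; within the scatter) and would remain inside the scatter. For compound 3 the estimated value is 35 nM with an expected range from 12 nM to 100 nM in this read-out.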

Compound 3, half-maximal inhibitory concentration: 90 nM
Compound 3: the middle estimate sits 2.6-fold (0.41 log units) below what was measured, within the range that was stated.
By their numbers in this assay, from the lowest: compounds 2 and 1 (each within the scatter of the next); then compound 3.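

In this assay, within the data shown here, chloro in place of hydrogen on the benzamido ring, para to a large group, gives a 2.8-fold higher number from compound 2 to compound 3 (0.45 log units; beyond the scatter) and is the first single change to move the number beyond the scatter. It is also the first change shown on this ring, so this carbon is not indifferent to substitution, at least for chloro, and the rise runs towards weaker inhibition. The level standing of compound 1 and compound 2 does not carry over to the chlorinated group, as ((4-chlorophenyl)carbonyl)amino in place of hydroxy gives a 2.3-fold higher number from compound 1 to compound 3 (0.35 log units; beyond the scatter) on the read-out, and no accompanying data bear on the reason for this rise.

The compounds shown leave open whether the rise belongs to chloro itself or to any replacement of hydrogen on this carbon, which fluoro, methyl, an amine or a carboxylic acid at the same place would help to separate. They also leave open how far the step depends on place, since chloro appears on this ring at only one carbon.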